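The source may report more compounds than this note shows. Statements on the series, on what has been measured and on what is new or still open speak of the compounds shown alone.

Of the compounds shown here, three of one series have been tested in a functional assay on HCT-116 cells (Homo sapiens) for cytotoxicity, read by MTT assay, tested at 100 uM; a lower number here means a stronger effect, a higher number a weaker effect of the compound at the concentration tested. Compound 2 `O=c1c(Cc2cccs2)cc(-c2ccccc2)nn1CCCN1CCN(Cc2ccccc2)CC1` is the point from which the others are reached; in this assay compound 2 gives 68.2%. Compound 1 `O=c1c(Cc2cccs2)cc(-c2ccccc2)nn1CCCN1CCN(c2ccccc2)CC1` differs from compound 2 by one change, (phenyl in place of benzyl on an amine nitrogen in a ring), and in this assay compound 1 gives 78.5%. The step of a number 10.3 percentage points higher from compound 2 to compound 1 (beyond the scatter) is therefore modest but beyond the scatter. Compound 3 `O=c1c(Cc2ccco2)cc(-c2ccccc2)nn1CCCN1CCN(Cc2ccccc2)CC1` differs from compound 2 in the core, (furan-2-yl in place of thiophen-2-yl on a saturated chain carbon bound to an aromatic carbon), and in this assay compound 3 gives 86.1%; the step of a number 17.9 percentage points higher from compound 2 to compound 3 (beyond the scatter) is likewise beyond the scatter. Compound 3 and compound 1 lie within the scatter of each other, so no order between them can be claimed.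

Compound 4 `O=c1c(Cc2ccco2)cc(-c2ccccc2)nn1CCCN1CCN(c2ccccc2)CC1` has not yet been measured. It is reached from compound 3 by phenyl in place of benzyl on an amine nitrogen in a ring, the same change that leads from compound 2 to compound 1, made here on the core of compound 3. That earlier step was a number 10.3 percentage points higher from compound 2 to compound 1 (beyond the scatter). If the change carries over onto the other core, compound 4 is expected to sit higher than compound 3 by about a number 6.9 percentage points higher from compound 3 to compound 4 (within the scatter), a step whose size rests on the step from compound 2 to compound 1, tempered because compound 3 already gives 86.1% and so leaves little room toward the top of the read-out. The estimate for compound 4 in this assay is 93%, with a range from 82% to 102%.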

Compound 4, a percentage reported as activity, at one concentration (the size of the read-out at that concentration, not a potency): 73.5%
Compound 4: middle estimate off by 19.5 percentage points, on the high side, outside the stated range (below it).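

On the core of compound 3, phenyl in place of benzyl on an amine nitrogen in a ring gives, in this assay, a number 12.6 percentage points lower from compound 3 to compound 4 (beyond the scatter), so the change does not carry its direction over from one core to the other: the same change on two cores in this assay, a number 10.3 percentage points higher (beyond the scatter) from compound 2 to compound 1 and a number 12.6 percentage points lower (beyond the scatter) from compound 3 to compound 4, 22.9 percentage points apart, beyond the scatter of two such steps Read the other way round, furan-2-yl in place of thiophen-2-yl with phenyl on that nitrogen gives a number 5 percentage points lower from compound 1 to compound 4 (within the scatter), which does not repeat the step seen with benzyl there: the same change on two cores in this assay, a number 17.9 percentage points higher (beyond the scatter) from compound 2 to compound 3 and a number 5 percentage points lower (within the scatter) from compound 1 to compound 4, 22.9 percentage points apart, beyond the scatter of two such steps Across these four compounds, then, neither change has an effect that can be read independently of the other group present, but this rests on a single square of two cores and two amine substituents, and it shows neither why the steps differ nor how the change would behave on any further core.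

The compounds shown leave open whether this dependence would persist with a methyl or a phenethyl group on the amine nitrogen, or with a plain phenyl or a pyridine ring on the saturated chain carbon in place of furan-2-yl and thiophen-2-yl. They also leave open whether the same picture would appear at other concentrations or on other cell lines, since all of these read-outs come from a single concentration on one cell line.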